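The compounds below may be only part of what the source reports. "The series", "measured", "known", "first", "only" and "open" are said of these compounds alone.

In an ADME assay on microsomes from liver (Homo sapiens) for metabolic stability, read by LC-MS, with a stated time of 10 min (on this read-out lower numbers stand for a less stable compound and higher numbers for a more stable compound), compound 1 (`c1cnc2c(c1)CCC[C@@H]2N(CC1CC1)C[C@H]1Cc2c(cccc2N2CCNCC2)CN1`) gives 82.1% and compound 2 (`CC(C)N1CCN(c2cccc3c2C[C@H](CN(C)[C@H]2CCCc4cccnc42)NC3)CC1`) gives 56.6% as the lower of the two numbers, a gap beyond the scatter. Compound 3 (`CN1CCN(c2cccc3c2C[C@H](CN(C)[C@H]2CCCc4cccnc42)NC3)CC1`) differs from compound 2 in one place: the change methyl in place of isopropyl on an amine nitrogen in a ring puts methyl in place of isopropyl on an amine nitrogen in a ring. Among the measured compounds shown here, no measured step covers this change, so the expectation is loose. A small upward move within the scatter is expected, with a number 5.4 percentage points higher from compound 2 to compound 3 (within the scatter) as the estimated step. For compound 3 the estimate in this assay is 62% with an expected range from 45% to 78% for repeat measurements.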

Compound 3, percent of the compound remaining: 75.8%
Estimate against measurement, compound 3: 13.8 percentage points below, within the range that was stated.
By their numbers in this assay, from the lowest: compound 2; then compounds 3 and 1 (each within the scatter of the next).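

In this assay, among the compounds shown here, replacing 4-isopropylpiperazin-1-yl with 4-methylpiperazin-1-yl gives a number 19.2 percentage points higher from compound 2 to compound 3 (beyond the scatter) and provides the first single-change comparison. The substituent on this amine nitrogen in a ring therefore affects the read-out on this core, although the finding rests on one pair. No supporting measurement bears on the reason for the rise.

As far as these compounds go, whether ethyl or acetyl on the same nitrogen would give a similar number remains open. Also open, from the compounds shown here alone, is whether the same replacement would have a similar effect with the other groups on the core held differently.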